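Tert-butyl for phenyl in a bis(trifluoromethyl) sulfonamide series

The source may hold more compounds than are shown below. What is called first, only, known or untested is meant among the compounds shown, and "the series" means these compounds.

Three compounds have been measured in a toxicity assay on MCF-10A cells (Homo sapiens) for inhibition, read by MTT assay, with a stated time of 72 h; on this read-out higher numbers stand for weaker inhibition of growth and lower numbers for stronger inhibition of growth:

Compound 1, `CC(C)(C)c1ccc(CNCCCNS(=O)(=O)c2cc(C(F)(F)F)cc(C(F)(F)F)c2)cc1`: 3200 nM
Compound 2, `O=S(=O)(NCCNCc1ccc(-c2ccccc2)cc1)c1cc(C(F)(F)F)cc(C(F)(F)F)c1`: 3300 nM
Compound 3, `O=S(=O)(NCCCNCc1ccc(-c2ccccc2)cc1)c1cc(C(F)(F)F)cc(C(F)(F)F)c1`: 2800 nM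

Compound 3 and compound 1 differ by one change, (tert-butyl in place of phenyl on an aromatic carbon), and that change gave a 1.1-fold higher number from compound 3 to compound 1 (0.06 log units; within the scatter). Compound 2 shares the sulfonamide and the phenyl-bearing end with compound 3, but the difference between the two cores is not broken down here; in this assay compound 2 gives 3300 nM and compound 3 gives 2800 nM, and the two numbers lie within the scatter of each other.

Compound 4, `CC(C)(C)c1ccc(CNCCNS(=O)(=O)c2cc(C(F)(F)F)cc(C(F)(F)F)c2)cc1`, has not yet been measured. It stands to compound 2 as compound 1 stands to compound 3: the change is tert-butyl in place of phenyl on an aromatic carbon, the same change, at the same place. Since that change gave a 1.1-fold higher number from compound 3 to compound 1 (0.06 log units; within the scatter), an equally small step, a 1.1-fold higher number from compound 2 to compound 4 (0.03 log units; within the scatter), is expected, with compound 2 at 3300 nM as its starting point. For compound 4 the estimate in this assay is 3500 nM, expected to fall between 1800 nM and 7000 nM.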

Compound 4, concentration for 50% growth inhibition: 14000 nM
The estimate for compound 4 lay 4.0-fold (0.60 log units) below the measured number; the measured number lies above the stated range.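

In this assay, tert-butyl in place of phenyl on an aromatic carbon gave a 4.2-fold higher number from compound 2 to compound 4 (0.63 log units; beyond the scatter), a modest step, and the two cores did not respond alike to this one change: the same change on two cores in this assay, a 1.1-fold higher number (0.06 log units; within the scatter) from compound 3 to compound 1 and a 4.2-fold higher number (0.63 log units; beyond the scatter) from compound 2 to compound 4, 3.7-fold (0.57 log units) apart, beyond the scatter of two such steps. On these two pairs, then, the step read on one core did not carry over to the other, and the core the change sits on matters to its size. Going by these compounds alone, this does not show what in the cores separates the two steps, and with only two pairs it does not say which step a further core would resemble.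

The compounds shown leave open whether the same change on a core with a still longer chain would give a step as small as that on the core of compound 3 or one as large as that on the core of compound 2. They also leave open how a cyclohexyl group or a trifluoromethyl group in place of phenyl would behave on either core.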